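The source may hold more compounds than are shown below. What is called first, only, known or untested is meant among the compounds shown, and "the series" means these compounds.

Measured so far:
compound 1, `CCS(=O)(=O)CCOc1cc(C)c(-c2cccc(COc3ccc4c(c3)OC[C@H]4CC(=O)O)c2)c(C)c1`, 2.73
compound 2, `Cc1c(C)c(-c2cccc(COc3ccc4c(c3)OC[C@H]4CC(=O)O)c2)c(C)c(C)c1OC1CCS(=O)(=O)CC1`, 3.35
compound 3, `Cc1cc(OCC2(O)CCS(=O)(=O)CC2)cc(C)c1-c1cccc(COc2ccc3c(c2)OC[C@H]3CC(=O)O)c1`, 2.43

In a physicochemical assay for lipophilicity, read by HPLC, at pH 7.4 (a lower number here means a more polar compound, a higher number a more lipophilic compound), compound 3 stands lowest of the three numbers; compound 1 is closest to it and the gap between them lies within the scatter, while compound 2 sits further off, beyond the scatter. For the measured compounds named here, the only measured step that touches this position, a number 0.30 log units lower from compound 1 to compound 3 (within the scatter), shows that swapping one sulfone-bearing group for another on the saturated chain carbon bound to the oxygen on the aromatic ring left the read-out essentially unchanged.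

Compound 4, `Cc1nc(C)c(COc2cc(C)c(-c3cccc(COc4ccc5c(c4)OC[C@H]5CC(=O)O)c3)c(C)c2)s1`, carries a different change at the same place: 2,4-dimethyl-1,3-thiazol-5-yl in place of 4-hydroxy-1,1-dioxothian-4-yl on a saturated chain carbon bound to an oxygen on an aromatic ring. Going by the values given here, no measured step exchanges a sulfone-bearing group for an aromatic one, so the expectation rests on what the values of compound 3 and compound 2 show, namely that the numbers at this position can move by about the width of that gap. For compound 4 an upward step is expected, a number 1.37 log units higher from compound 3 to compound 4 (beyond the scatter), beyond the scatter. The estimate for compound 4 in this assay is 3.8, within a range from 3.3 to 4.3.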

Compound 4, distribution coefficient: 4.27
Compound 4: the middle estimate sits 0.47 log units below what was measured, within the range that was stated.
By their numbers in this assay, from the lowest: compounds 3 and 1 (each within the scatter of the next); then compound 2; then compound 4.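

In this assay this position turns out to allow a large move: the thiazole change gives a number 1.84 log units higher from compound 3 to compound 4 (beyond the scatter), and it also gives a number 1.54 log units higher from compound 1 to compound 4 (beyond the scatter), both beyond the scatter, whereas the earlier exchange of one sulfone-bearing group for the other gave only a number 0.30 log units lower from compound 1 to compound 3 (within the scatter). On the saturated chain carbon bound to an oxygen on an aromatic ring, the two sulfone-bearing groups therefore read alike, while 2,4-dimethyl-1,3-thiazol-5-yl stands clearly apart from both. No independent evidence bearing on this result is at hand.

The compounds shown do not tell whether the step follows the aromatic ring itself or its two methyl groups; an unsubstituted thiazole or a pyridine at this place would bear on that. Nor do they tell how a group carrying an amine would read here.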